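A few compounds are considered here, and "the series" means these few. Any claim that something is new, unique, unknown or untested is made for them only; others in the source may bear on it.

Compound 2 `c1ccc2c(-c3cn4ccnc4c(-c4ccc5ncn(C6CCCCC6)c5c4)n3)cccc2c1` stands second highest of three numbers in a functional assay on MCF7 cells (Homo sapiens) for inhibition, read by sulforhodamine B assay, with a stated time of 48 h, tested at 10 uM (a lower number here means less inhibition, a higher number more inhibition at the concentration tested (going by the name of the read-out)), where compound 2 gives 13%. Compound 1 `O=Cc1ccc(-c2cn3ccnc3c(-c3ccc4ncn(C5CCCCC5)c4c3)n2)cc1` gives 47.8%, and compound 3 `Fc1ccc(-c2cn3ccnc3c(-c3ccc4ncn(C5CCCCC5)c4c3)n2)cc1` gives 9.17%. Compound 4 `Brc1ccc(-c2cn3ccnc3c(-c3ccc4ncn(C5CCCCC5)c4c3)n2)cc1` is not yet measured; the change from compound 2 is 4-bromophenyl in place of naphthalen-1-yl on an aromatic carbon. The step that bears most directly on it is a number 3.8 percentage points lower from compound 2 to compound 3 (within the scatter), which replaces the same naphthalen-1-yl with 4-fluorophenyl and stays within the scatter. The large steps of a number 34.8 percentage points lower from compound 1 to compound 2 (beyond the scatter) and a number 38.6 percentage points lower from compound 1 to compound 3 (beyond the scatter) both start from the formyl compound and say little about a bromo for fluoro exchange. No shift beyond the scatter is therefore expected; for compound 4 the expected step is a number 1 percentage points lower from compound 2 to compound 4 (within the scatter). Compound 4 is estimated at 12%, between 3% and 25%.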

Compound 4, a percentage reported as inhibition, at one concentration (the size of the read-out at that concentration, not a potency): 46.4%
Compound 4: the middle estimate sits 34.4 percentage points below what was measured, outside the stated range (above it).
By their numbers in this assay, from the lowest: compounds 3 and 2 (each within the scatter of the next); then compounds 4 and 1 (each within the scatter of the next).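

In this assay, the substituent on the aryl group decides the level: bromo in place of fluoro gives a number 37.2 percentage points higher from compound 3 to compound 4 (beyond the scatter) and so separates two otherwise identical compounds. 4-Bromophenyl in place of naphthalen-1-yl gives a number 33.4 percentage points higher from compound 2 to compound 4 (beyond the scatter) even though the step to 4-fluorophenyl stayed within the scatter, while bromo in place of formyl gives a number 1.4 percentage points lower from compound 1 to compound 4 (within the scatter) and shows that the higher level does not depend on formyl alone. No measurement shown here accounts for this split between bromo and fluoro. Open, as far as these compounds go, is whether chloro, methoxy, an amine or a carboxylic acid in place of bromo would stay level with compound 4 or with compound 3.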